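Compound 4 against a near-limit series

The source may hold more compounds than are shown below. What is called first, only, known or untested is meant among the compounds shown, and "the series" means these compounds.

In a functional assay on HT-29 cells (Homo sapiens) for inhibition, read by sulforhodamine B assay (on this read-out higher numbers stand for weaker inhibition and lower numbers for stronger inhibition), compound 1 `COC(=O)CC/C(C)=C/Cc1c(OC)c(C)c2c(c1OCC#CCN1CCCc3ccccc31)C(=O)OC2` gives > 50000 nM, which is a limit of the assay and not a number. Compound 2 `COC(=O)CC/C(C)=C/Cc1c(OC)c(C)c2c(c1OCC#CCN1CCC(Cc3ccccc3)CC1)C(=O)OC2` gives > 50000 nM, again a limit. Going by the values given here, compound 3 `CCCCNc1ccc(CC#CCOc2c(C/C=C(\C)CCC(=O)OC)c(OC)c(C)c3c2C(=O)OC3)cc1` gives 36700 nM, the only actual number so far.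

Compound 4 `COC(=O)CC/C(C)=C/Cc1c(OC)c(C)c2c(c1OCC#CCN1CCC(C(=O)OC)CC1)C(=O)OC2` carries 4-(methoxycarbonyl)piperidin-1-yl in place of 4-(butylamino)phenyl on a saturated chain carbon bound to a triple-bonded carbon.

Among the compounds with values here, the one measured step at this place is an at least 1.3-fold lower number from compound 1 to compound 3 (0.13 log units; that floor lies within the scatter). It gives no sign that changing this group moves this assay beyond the scatter. The expectation also leans on (the limit of > 50000 nM in this assay, at which 2 of the 3 values shown sit), so a report of only a limit is expected to be about as likely as a number for compound 4. The expected move is a 1.2-fold higher number from compound 3 to compound 4 (0.09 log units; within the scatter), which would be no step beyond the scatter. For compound 4 the estimated value is 45000 nM, with an expected range of 20000 nM to 90000 nM.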

Compound 4, half-maximal inhibitory concentration: > 50000 nM
Compound 4 was reported as a limit; the forecaster's own chance of this, stated with the estimate: 60%; at least 1.1-fold (0.04 log units) between middle value and limit.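

In this assay, the change to 4-(methoxycarbonyl)piperidin-1-yl at this place gives an at least 1.3-fold higher number from compound 3 to compound 4 (0.13 log units; that floor lies within the scatter), so the size of the step cannot be separated from the scatter. Compound 4 is a third report at a limit, and the steps to it from compound 1 and compound 2 cannot be read. Among the compounds shown, those with a ring nitrogen on the saturated chain carbon (compound 1, compound 2, compound 4) all stand at a limit, and only the 4-(butylamino)phenyl of compound 3 gives a number, leaving little measured range in the series: the limit of > 50000 nM in this assay, at which 3 of the 4 values shown sit.

Going by these compounds, how the three limit compounds rank against one another remains open. Also open, on these data alone, is whether a carboxylic acid in place of methoxycarbonyl, or a longer chain in place of butyl on the amine of compound 3, would give a number in this assay.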